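The source may report more compounds than this note shows. Statements on the series, on what has been measured and on what is new or still open speak of the compounds shown alone.

Working notes on the series. Compound 1 `O=C1NCCN1CCCCCCN1CCC(c2cn(-c3ccc(F)cc3)c3ccc(Cl)cc23)CC1` was tested in a functional assay on the whole organism for inhibition, with Rattus norvegicus as the target; on this read-out lower numbers stand for an effect already at smaller amounts and higher numbers for an effect only at larger amounts of compound. Compound 1 gives only a limit there, > 2.2 umol/kg, and no number. Compound 2 `O=C1NCCN1CCN1CC=C(c2cn(-c3ccc(F)cc3)c3ccc(C(F)(F)F)cc23)CC1` is the other measured member of the set. In this assay compound 2 also gives only a limit, > 0.66 umol/kg. Compound 1 therefore stands at no definite point on the numbers shown: the two marks are the limit of > 2.2 umol/kg in this assay, at which 1 of the 2 values shown sits, and (the limit of > 0.66 umol/kg in this assay, at which 1 of the 2 values shown sits), and no step between measured compounds can be drawn from them. Compound 3 `O=C1NCCN1CCCCCN1CCC(c2cn(-c3ccc(F)cc3)c3ccc(Cl)cc23)CC1` has not been measured in this assay. It differs from compound 1 in one place: 2-oxoimidazolidin-1-yl in place of (2-oxoimidazolidin-1-yl)methyl on a saturated chain carbon, five bonds along the chain from an amine nitrogen in a ring. The change leaves a shorter chain between the amine nitrogen in a ring and the 2-oxoimidazolidin-1-yl group. Among the measured compounds shown here, no measured step in this set shows what such a shortening does, and compound 2 differs in more than one place, so nothing can be read across. The step that the limit leaves unreadable from compound 1 to compound 3 is expected to be none beyond the scatter. A limit rather than a number is also expected for compound 3, as compound 1 gives > 2.2 umol/kg. The estimate for compound 3 in this assay is 3 umol/kg, within 1 umol/kg to 10 umol/kg.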

Compound 3, dose for half-maximal effect: 1.5 umol/kg
The estimate for compound 3 lay 2.0-fold (0.30 log units) above the measured number; measured number inside the range.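

Among the compounds shown here, compound 3 is the first member of the set to give a number and not a limit in this assay, so this series now has one definite mark on this read-out. At the saturated chain carbon, five bonds along the chain from an amine nitrogen in a ring, 2-oxoimidazolidin-1-yl in place of (2-oxoimidazolidin-1-yl)methyl gives an at least 1.4-fold lower number from compound 1 to compound 3 (0.16 log units; that floor lies within the scatter); the shorter chain therefore keeps a measurable effect in the whole animal, while the floor of the step does not establish a gain beyond the scatter. The true size of the step stays unknown because compound 1 gives a limit and not a number: the limit of > 2.2 umol/kg in this assay, at which 1 of the 3 values shown sits.

The steps from compound 2 to the other compounds cannot be read, as it differs from them in more than one place and gives only a limit. Still open, on these data alone, are how a still shorter chain or a longer chain would read on the same core, and whether a carboxylic acid or a plain amine in place of 2-oxoimidazolidin-1-yl would keep a measurable effect.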